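Moving a fluorine across the ring on a shared core

A few compounds are considered here, and "the series" means these few. Any claim that something is new, unique, unknown or untested is made for them only; others in the source may bear on it.

Four close relatives of one scaffold are compared here, all tested in a functional assay on MKN-45 cells (Homo sapiens) for cytotoxicity, read by MTT assay, with a stated time of 72 h; on this read-out lower numbers stand for stronger inhibition and higher numbers for weaker inhibition. Compound 1, with structure `COc1cc2c(Oc3ccc(NC(=O)c4cc(-c5ccc(F)cc5)ccn4)cc3F)ccnc2cc1OCCCN1CCCCC1`, is the reference point; in this assay compound 1 gives 1240 nM. Compound 2, `COc1cc2c(Oc3ccc(NC(=O)c4cc(-c5ccccc5F)ccn4)cc3F)ccnc2cc1OCCCN1CCCCC1`, differs from compound 1 by 2-fluorophenyl in place of 4-fluorophenyl on an aromatic carbon, and in this assay compound 2 gives 180 nM. This change made a step of a 6.9-fold lower number from compound 1 to compound 2 (0.84 log units; beyond the scatter). Compound 3, `COc1cc2c(Oc3ccc(NC(=O)c4cc(-c5ccc(F)cc5)ccn4)cc3F)ccnc2cc1OCCCN1CCCC1`, differs from compound 1 in the chain end instead: pyrrolidin-1-yl in place of piperidin-1-yl on a saturated chain carbon, three bonds along the chain from an oxygen on an aromatic ring. In this assay compound 3 gives 350 nM, a step of a 3.5-fold lower number from compound 1 to compound 3 (0.55 log units; beyond the scatter). Compound 2 and compound 3 sit within the usual scatter of each other, so no order between them is claimed.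

Compound 4, `COc1cc2c(Oc3ccc(NC(=O)c4cc(-c5ccccc5F)ccn4)cc3F)ccnc2cc1OCCCN1CCCC1`, has not yet been measured. It carries the change (2-fluorophenyl in place of 4-fluorophenyl on an aromatic carbon), the same change already seen from compound 1 to compound 2, on the core of compound 3 rather than the core of compound 1; the two cores differ as described by pyrrolidin-1-yl in place of piperidin-1-yl on a saturated chain carbon, three bonds along the chain from an oxygen on an aromatic ring. The place of the change is the same in both pairs, so it is treated as the same change.

Because the earlier step was a 6.9-fold lower number from compound 1 to compound 2 (0.84 log units; beyond the scatter), a similar but possibly smaller step is expected here, since the starting value of compound 3 is already lower; the expected step is a 5.4-fold lower number from compound 3 to compound 4 (0.73 log units; beyond the scatter). Compound 4 is estimated to give about 65 nM, within a range from 25 nM to 180 nM.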

Compound 4, half-maximal inhibitory concentration: 230 nM
Beside the measured number, compound 4's estimate is 3.5-fold (0.55 log units) below it; the measured number lies above the stated range.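

Moving the fluorine to give 2-fluorophenyl in place of 4-fluorophenyl on the core of compound 3 produces a 1.5-fold lower number from compound 3 to compound 4 (0.18 log units; within the scatter), so in this assay the clear gain seen on the core of compound 1 does not carry over to this second core: the same change on two cores in this assay, a 6.9-fold lower number (0.84 log units; beyond the scatter) from compound 1 to compound 2 and a 1.5-fold lower number (0.18 log units; within the scatter) from compound 3 to compound 4, 4.5-fold (0.66 log units) apart, beyond the scatter of two such steps. Read the other way, putting pyrrolidin-1-yl in place of piperidin-1-yl on the 2-fluorophenyl core produces a 1.3-fold higher number from compound 2 to compound 4 (0.11 log units; within the scatter), and this step also differs from the one seen with the 4-fluorophenyl group: the same change on two cores in this assay, a 3.5-fold lower number (0.55 log units; beyond the scatter) from compound 1 to compound 3 and a 1.3-fold higher number (0.11 log units; within the scatter) from compound 2 to compound 4, 4.5-fold (0.66 log units) apart, beyond the scatter of two such steps. Within these four compounds, then, each change lowers the number when made alone on compound 1, but the two do not add up when combined, and the data show neither why this happens nor whether it would hold on any other core.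

From the compounds shown here alone, it remains open whether a plain phenyl group, or a chlorine in place of the fluorine, would depend on the chain end in the same way. Going by these compounds, it is equally open whether a morpholine or a dimethylamine at the end of the chain, or a longer chain, would behave like pyrrolidin-1-yl or like piperidin-1-yl.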